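Swapping the Aryl Group in a Series Inert to HeLa Cells

The source may report more compounds than this note shows. Statements on the series, on what has been measured and on what is new or still open speak of the compounds shown alone.

Compound 1 `O=C(/C=C\c1ccc(O)cc1)N1N=C(c2ccncc2)OC1c1c[nH]c2ccccc12` — in an ADME assay on HeLa cells (Homo sapiens) for cytotoxicity, read by MTT assay, with a stated time of 72 h (a higher number here means a weaker inhibitor of growth, a lower number a stronger inhibitor of growth), compound 1 gives > 30 ug/mL, a limit of the assay rather than a number.
Compound 2 `COc1ccc(/C=C\C(=O)N2N=C(c3ccncc3)OC2c2c[nH]c3ccccc23)cc1` — in this assay compound 2 gives > 30 ug/mL, again a limit and not a number.

Compound 2 therefore stands at the limit of > 30 ug/mL in this assay, at which 2 of the 2 values shown sit, the same limit at which compound 1 sits. Among the compounds with values here, the one measured step, a step that the two limits leave unreadable from compound 1 to compound 2, cannot be sized, since both of its ends are limits. Compound 3 `O=C(/C=C\c1ccccc1Cl)N1N=C(c2ccncc2)OC1c1c[nH]c2ccccc12` differs from compound 2 by 2-chlorophenyl in place of 4-methoxyphenyl on a double-bonded chain carbon bound to a double-bonded chain carbon. Within the data shown here, no measured step bears directly on this change, as the only step between measured compounds concerns methyl in place of hydrogen on an oxygen on an aromatic ring, and even that step is unreadable. The expectation for compound 3 in this assay rests on compound 2 standing at the limit of > 30 ug/mL in this assay, at which 2 of the 2 values shown sit, so no step beyond the scatter is expected in either direction. The step expected from this change is a step that the limit leaves unreadable from compound 2 to compound 3. Compound 3 is estimated at 40 ug/mL, with a range from 15 ug/mL to 120 ug/mL, and it is most likely to be reported once more as a limit.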

Compound 3, concentration for 50% growth inhibition: > 30 ug/mL
Compound 3 ended at the assay's limit; the forecaster's own chance of this, stated with the estimate: 75%; the middle value lies beyond the limit too.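

Within the data shown here, compound 1, compound 2 and compound 3 all end at the same limit of the assay rather than at a number in this assay, so no step among them can be read: the limit of > 30 ug/mL in this assay, at which 3 of the 3 values shown sit.

The compounds shown leave open how far each lies past that limit, and whether any other group in this place would give a readable number.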